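The source may report more compounds than this note shows. Statements on the series, on what has been measured and on what is new or still open speak of the compounds shown alone.

Measured so far:
compound 1, `COc1ccc(F)cc1Nc1cc(NC(=O)Nc2c(Cl)cccc2Cl)ncn1`, 73.1%
compound 2, `COc1cc(NC(=O)Nc2cc(Nc3cc(C(F)(F)F)ccc3OC)ncn2)cc(OC)c1`, 67.1%

In a functional assay on NCI-H1581 cells (Homo sapiens) for inhibition, read by MTT assay, with a stated time of 48 h, tested at 10 uM (a lower number here means less inhibition, a higher number more inhibition at the concentration tested (going by the name of the read-out)), compound 1 gives 73.1% and compound 2 gives 67.1%; the gap between the two lies within the usual scatter, so neither can be set apart from the other. Compound 3, `COc1ccc(Nc2cc(NC(=O)Nc3c(Cl)cccc3Cl)ncn2)cc1C`, has not yet been measured. It differs from compound 1 in one place: 4-methoxy-3-methylphenyl in place of 5-fluoro-2-methoxyphenyl on a nitrogen on an aromatic ring. For the measured compounds named here, no measured pair shows what such a swap does here, so the expected step is a number 7.1 percentage points lower from compound 1 to compound 3 (within the scatter), a size not beyond the scatter. Compound 3 is expected to give about 66%, within a range from 45% to 85%.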

Compound 3, a percentage reported as inhibition, at one concentration (the size of the read-out at that concentration, not a potency): 45.1%
Estimate against measurement, compound 3: 20.9 percentage points above; low and high end bracket the measured number.
By their numbers in this assay, from the lowest: compound 3; then compounds 2 and 1 (each within the scatter of the next).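

In this assay, the group on this nitrogen cannot be swapped freely: 4-methoxy-3-methylphenyl in place of 5-fluoro-2-methoxyphenyl gives a number 28 percentage points lower from compound 1 to compound 3 (beyond the scatter). For the compounds shown here, this is the first change in a single place, and it shows that the read-out responds to this position even when both groups have the same count of heavy atoms. No information at hand explains the drop.

Going by these compounds, the swap removes the fluorine, adds a methyl and rearranges the methoxy all at once, so which of these matters remains open. On these data alone, how an amine or a carboxylic acid on that ring would behave also remains open.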